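A Longer Tether to the Phenyl Group

The source may hold more compounds than are shown below. What is called first, only, known or untested is meant among the compounds shown, and "the series" means these compounds.

Compound 2 `CCCCOc1ccc2c(Cl)ccnc2c1` carries a butyl chain on the oxygen of the shared core. Within the data shown here, in a functional assay on BGC-823 cells (Homo sapiens) for cytotoxicity, read by MTT assay, with a stated time of 48 h (on this read-out higher numbers stand for weaker inhibition and lower numbers for stronger inhibition), compound 2 gives 3610 nM, the second highest of the three numbers measured so far. Its nearest neighbour is compound 1 `CC(C)Oc1ccc2c(Cl)ccnc2c1`, which gives 2630 nM in this assay; the most distant is compound 3 `Clc1ccnc2cc(OCc3ccccc3)ccc12`, which gives 5170 nM. Neither gap is large: the step of a 1.4-fold higher number from compound 1 to compound 2 (0.14 log units; within the scatter) and the step of a 1.4-fold higher number from compound 2 to compound 3 (0.16 log units; within the scatter) both sit inside the scatter of repeated measurements, so nothing separates these three compounds with confidence.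

Compound 4 `Clc1ccnc2cc(OCCc3ccccc3)ccc12` has not yet been measured. Relative to compound 2 the change is phenyl in place of ethyl on a saturated chain carbon, two bonds along the chain from an oxygen on an aromatic ring. The step that bears most directly on this is a 1.4-fold higher number from compound 2 to compound 3 (0.16 log units; within the scatter), where phenyl also took the place of propyl on a saturated chain carbon bound to an oxygen on an aromatic ring. The step of a 1.4-fold higher number from compound 1 to compound 2 (0.14 log units; within the scatter) shows that reshaping the alkyl part changed little as well. On this basis no move beyond the scatter is expected in this assay, with at most a slight lean toward a higher number. Compound 4 is therefore estimated at 4500 nM, with a range of 2200 nM to 9000 nM. The expected step is a 1.2-fold higher number from compound 2 to compound 4 (0.10 log units; within the scatter).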

Compound 4, half-maximal inhibitory concentration: 2010 nM
Estimate against measurement, compound 4: 2.2-fold (0.35 log units) above; measured number outside the range, below it.
By their numbers in this assay, from the lowest: compounds 4, 1, 2 and 3 (each within the scatter of the next, the first and the last beyond it).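

Putting phenyl in place of ethyl at this position adds a whole aromatic ring to the end of the chain, yet the result is a 1.8-fold lower number from compound 2 to compound 4 (0.25 log units; within the scatter), so in this assay this larger group costs nothing that can be told apart from compound 2. Among these compounds, what the earlier compounds could not show is that the length of the chain carrying the phenyl may matter: compound 3 gives 5170 nM and compound 4 gives 2010 nM, and these two compounds, which differ only in that chain, are the one pair among the four whose numbers lie beyond the scatter of each other. No measurement here accounts for this difference, so the reason for it remains unknown.

From the compounds shown here alone, one pair cannot establish a trend, so it remains open whether a still longer chain carrying the phenyl would continue in the direction of compound 4 or would return toward compound 3. Going by these compounds, it is equally open how the numbers would respond if the end of the chain held an amine or a carboxylic acid in place of the phenyl.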